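A few compounds are considered here, and "the series" means these few. Any claim that something is new, unique, unknown or untested is made for them only; others in the source may bear on it.

Compound 1, `COc1ccc(-c2cnc(NC(=O)c3ccccc3O)n2C)cc1`, in a toxicity assay on THP-1 cells (Homo sapiens) for inhibition (a higher number here means that more compound is tolerated, a lower number that less compound is tolerated), sits at > 100000 nM, a limit of the assay and not a number.
Compound 2, `COc1ccc(-c2cnc(NC(=O)c3cccc([N+](=O)[O-])c3)n2C)cc1`, in this assay sits at > 100000 nM, again a limit and not a number.
Compound 3, `Cn1c(-c2ccccc2)cnc1NC(=O)c1ccccc1`, in this assay sits at > 100000 nM, once more a limit and not a number.

Compound 1 therefore stands where every measured compound stands: at the limit of > 100000 nM in this assay, at which 3 of the 3 values shown sit. No pair among these three differs in a single place, so no step between measured compounds can be read, and nothing on the numbers sets compound 1 apart from compound 2 or compound 3.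

The next compound, compound 4, `COc1ccc(-c2cnc(NC(=O)c3ccccc3F)n2C)cc1`, differs from compound 1 in one place: fluoro in place of hydroxy on an aromatic carbon. Within the data shown here, no measured step shows what such an exchange does in this assay, and the three values so far give no spread to anchor a direction. The expected step of a number no higher from compound 1 to compound 4 (the limit leaves the size open) is therefore none beyond the usual scatter. Compound 4 is expected to come out at about 100000 nM, within 50000 nM to 200000 nM, most likely again as a limit rather than a number.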

Compound 4, half-maximal cytotoxic concentration: > 100000 nM
Compound 4: a limit, no number (the forecaster's own chance of this, stated with the estimate: 80%); the middle value sits exactly at the limit.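

Compound 1 and compound 4 both stand at a limit and not a number in this assay, so no step between them can be read: the limit of > 100000 nM in this assay, at which 4 of the 4 values shown sit.

The compounds shown leave open what concentration, if any, would harm these cells, and whether fluoro in place of hydroxy alters it.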